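This account rests on a few compounds, and the source may have more. Where it says the series, first, only, none or still open, it means among the compounds named here.

Compound 1 `COc1ccc(C(=O)/C(=C/c2ccc(Cl)cc2Cl)CC(C)C)cc1` gives 80300 nM in a functional assay on A549 cells (Homo sapiens) for inhibition, read by XTT assay, with a stated time of 48 h; on this read-out lower numbers stand for stronger inhibition and higher numbers for weaker inhibition. Compound 2 `COc1ccc(C(=O)/C(=C/c2ccc(Cl)cc2Cl)CC2CCCCC2)cc1` is recorded in this assay only as a limit, > 100000 nM, a standing described by the limit of > 100000 nM in this assay, at which 1 of the 2 values shown sits. Within the data shown here, the only measured step, an at least 1.2-fold higher number from compound 1 to compound 2 (0.09 log units; that floor lies within the scatter), concerns a different change. Compound 3 `COc1ccc(C(=O)/C(=C/c2ccc(Cl)cc2Cl)CN(C)C(=O)c2ccccc2)cc1` differs from compound 2 by benzoyl(methyl)amino in place of cyclohexyl on a saturated chain carbon bound to a double-bonded chain carbon. That measured step does not bear on this change, and since compound 2 stands at a limit no direction can be read from the numbers. The step expected is a number no higher from compound 2 to compound 3 (the limit leaves the size open), within the scatter. Compound 3 is therefore estimated at 100000 nM, with a range from 30000 nM to 300000 nM.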

Compound 3, half-maximal inhibitory concentration: 32400 nM
Estimate against measurement, compound 3: 3.1-fold (0.49 log units) above; the measured number falls inside the stated range.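

Among these compounds, at this position the group's kind now shows in the number: benzoyl(methyl)amino, the only group here with nitrogen, oxygen and an aromatic ring, gives a 2.5-fold lower number from compound 1 to compound 3 (0.39 log units; beyond the scatter) and an at least 3.0-fold lower number from compound 2 to compound 3 (0.48 log units; beyond the scatter). Compound 3 thus stands clear of both earlier compounds, which the isopropyl to cyclohexyl change alone could not show. The full size of the step from compound 2 stays open, as compound 2 is recorded only as a limit: the limit of > 100000 nM in this assay, at which 1 of the 3 values shown sits.

The compounds shown leave open which part of benzoyl(methyl)amino goes with the lower number. On these data alone, whether a dimethylamino or a benzyl group at this place would give the same lower number also stays open.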